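The compounds below may be only part of what the source reports. "The series", "measured", "known", "first", "only" and "open" are said of these compounds alone.

Measured compounds:
compound 1, `C=C(Br)C(=O)Nc1cccc(-c2cn3nc(-c4ccc(OC)c(OC)c4)sc3n2)c1`, 110 nM
compound 2, `C=C(Br)C(=O)Nc1cccc(-c2cn3nc(-c4ccc(C)cc4)sc3n2)c1`, 1200 nM
compound 3, `Nc1cccc(-c2cn3nc(Cc4ccc(Cl)cc4)sc3n2)c1`, 6000 nM

In a functional assay on FM3A cells (Mus musculus) for inhibition, read by cell counting, with a stated time of 2 days (a higher number here means a weaker inhibitor, a lower number a stronger inhibitor), compound 3 gives 6000 nM, the highest number of the three. Its nearest neighbour is compound 2, which in this assay gives 1200 nM; compound 1, the furthest, gives 110 nM in this assay. Both gaps lie beyond the scatter.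

The unmeasured compound 4, `C=C(Br)C(=O)Nc1cccc(-c2cn3nc(Cc4ccc(Cl)cc4)sc3n2)c1`, differs from compound 3 in one place: (1-bromoethenyl)carbonyl in place of hydrogen on a nitrogen on an aromatic ring. Going by the values given here, the one measured step, an 11-fold higher number from compound 1 to compound 2 (1.04 log units; beyond the scatter), concerns a different position, on the aromatic carbon, and so does not bear directly on this change. What the data do show is that compound 1 and compound 2, both carrying the ((1-bromoethenyl)carbonyl)amino group, sit well below compound 3 with its amino group, though their other substituents also differ, so no clean comparison exists.

On that basis compound 4 is expected to give a lower number than compound 3, with the step from compound 3 to compound 4 estimated at a 7.5-fold lower number from compound 3 to compound 4 (0.88 log units; beyond the scatter). Among the compounds with values here, the estimate for compound 4 in this assay is 800 nM, within a range from 150 nM to 4000 nM, the width reflecting that the step rests on no directly matched pair.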

Compound 4, half-maximal inhibitory concentration: 1100 nM
Compound 4: middle estimate off by 1.4-fold (0.14 log units), on the low side; the range from low to high includes it.
By their numbers in this assay, from the lowest: compound 1; then compounds 4 and 2 (each within the scatter of the next); then compound 3.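

In this assay, the change from amino to ((1-bromoethenyl)carbonyl)amino can now be read with the rest of the molecule held fixed: a 5.5-fold lower number from compound 3 to compound 4 (0.74 log units; beyond the scatter). Going by these compounds alone, earlier, this group could be compared only across compounds that also differed elsewhere, so this is the first direct measure of what it does on the nitrogen on an aromatic ring. With that group in place, the substituent on the aromatic carbon can also be read further: 4-chlorobenzyl in place of 4-methylphenyl gives a 1.1-fold lower number from compound 2 to compound 4 (0.04 log units; within the scatter), so these two groups cannot be told apart here, whereas 4-chlorobenzyl in place of 3,4-dimethoxyphenyl gives a 10-fold higher number from compound 1 to compound 4 (1.00 log units; beyond the scatter), leaving the 3,4-dimethoxyphenyl group clearly apart from both others.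

Still open, going by these compounds, is whether the step on the nitrogen would hold for an acetyl group or a 2-bromopropanoyl group, and whether it would be the same size with the 3,4-dimethoxyphenyl group on the aromatic carbon. No measurement shown here accounts for the size of any of these steps.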